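The compounds below may be only part of what the source reports. "The series", "measured", "known", "first", "only" and "open" are said of these compounds alone.

Of the compounds shown here, three have so far been measured in an ADME assay on microsomes from liver (Rattus norvegicus) for metabolic stability, read by LC-MS, using NADPH, at 37 degrees C; on this read-out lower numbers stand for a shorter-lived compound and higher numbers for a longer-lived compound. Compound 1 `Cc1ccccc1-c1nc(CN2CCC(C(=O)NCCCN3CC4CCCC(C4)C3)CC2)c(C)o1` gives 0.123 h in this assay, and compound 3 `Cc1cccc(Cl)c1-c1nc(CN2CCC(C(=O)NCCCN3CCC(C)(C)CC3)CC2)c(C)o1` gives 0.0733 h. Compound 2 `Cc1oc(-c2c(Cl)cccc2Br)nc1CN1CCC(C(=O)NCCCN2C[C@H](C)C[C@H](C)C2)CC1` stands lowest of the three with 0.0233 h; its nearest neighbour is compound 3, higher by more than the scatter, and compound 1 lies furthest, also beyond the scatter. Compound 4 `Cc1ccc(-c2nc(CN3CCC(C(=O)NCCCN4C[C@H](C)C[C@H](C)C4)CC3)c(C)o2)c(C)c1` carries one change from compound 2: 2,4-dimethylphenyl in place of 2-bromo-6-chlorophenyl on an aromatic carbon. Within the data shown here, no measured step of this kind exists, so the expectation rests on the whole set, in which compound 1 and compound 3 both read higher than compound 2. A modest rise, probably beyond the scatter, is expected: a 2.6-fold higher number from compound 2 to compound 4 (0.41 log units; beyond the scatter). Compound 4 is therefore estimated at 0.06 h, within a range from 0.02 h to 0.18 h.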

Compound 4, half-life: > 0.5 h
Compound 4 was reported as a limit (the forecaster's own chance of this, stated with the estimate: 5%); middle value at least 8.3-fold (0.92 log units) from the limit.
By their numbers in this assay, from the lowest: compound 2; then compounds 3 and 1 (each within the scatter of the next). At a limit, above all of these: compound 4.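

Placed on the aromatic carbon next to the ring nitrogen and next to the ring oxygen, 2,4-dimethylphenyl in place of 2-bromo-6-chlorophenyl gives an at least 21-fold higher number from compound 2 to compound 4 (1.33 log units; beyond the scatter) in this assay, the first step in the set that changes one place only. In this assay compound 4 gives > 0.5 h, which is a limit of the assay and not a number. The two groups hold the same count of heavy atoms, with carbon replacing chlorine and bromine.

No compound shown separates losing the halogens from adding the methyl groups. From the compounds shown here alone, how a methoxy group or a pyridine ring would read at this position also remains open.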